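This account rests on a few compounds, and the source may have more. Where it says the series, first, only, none or still open, it means among the compounds named here.

Compound 1 `CC(C)(C)C(=O)OC[C@H]1O[C@@H](n2cnc3c(Cl)ncnc32)C[C@@H]1O`: 177000 nM
Compound 2 `CCCC(=O)OC[C@H]1O[C@@H](n2cnc3c(Cl)ncnc32)C[C@@H]1O`: > 200000 nM (a limit, not a number)
Compound 3 `O=S(=O)(OC[C@H]1O[C@@H](n2cnc3c(Cl)ncnc32)C[C@@H]1O)c1ccccc1`: 146000 nM

These three results come from an ADME assay on Huh-7 cells (Homo sapiens) for cytotoxicity, read by XTT assay; a lower number here means that less compound is tolerated, a higher number that more compound is tolerated. Compound 3, at 146000 nM, lies within the scatter of compound 1, at 177000 nM. Compound 2 gives only a limit, > 200000 nM.

The next compound, compound 4 `C=CCOC[C@H]1O[C@@H](n2cnc3c(Cl)ncnc32)C[C@@H]1O`, keeps the shared core but carries allyl in place of phenylsulfonyl on an oxygen on a saturated carbon. Among the measured compounds shown here, no measured step makes this exact exchange. The closest evidence comes from changes to the group on the same oxygen. These are a 1.2-fold lower number from compound 1 to compound 3 (0.08 log units; within the scatter) and an at least 1.3-fold lower number from compound 2 to compound 3 (0.13 log units; that floor lies within the scatter), and the ester-to-ester change is an at least 1.1-fold higher number from compound 1 to compound 2 (0.05 log units; that floor lies within the scatter). None of these steps goes beyond the scatter, so no step beyond the scatter is expected in this assay, and the direction cannot be called with any confidence. The expected change is a 1.2-fold higher number from compound 3 to compound 4 (0.07 log units; within the scatter). Compound 4 may also end up at the limit of > 200000 nM in this assay, at which 1 of the 3 values shown sits, and then only a limit would be reported. The estimated value for compound 4 is 170000 nM, with an expected range from 90000 nM to 280000 nM.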

Compound 4, half-maximal cytotoxic concentration: 140000 nM
Estimate against measurement, compound 4: 1.2-fold (0.08 log units) above; the range from low to high includes it.
By their numbers in this assay, from the lowest: compounds 4, 3 and 1 (each within the scatter of the next). At a limit, above all of these: compound 2.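

In this assay, the group on the oxygen on a saturated carbon is now a small allyl with no ring and no hydrogen-bond acceptors, and a 1.0-fold lower number from compound 3 to compound 4 (0.02 log units; within the scatter) shows that removing phenylsulfonyl, with its six-membered aromatic ring, does not shift the number beyond the scatter. The comparisons with the two esters read the same way: a 1.3-fold lower number from compound 1 to compound 4 (0.10 log units; within the scatter), and an at least 1.4-fold lower number from compound 2 to compound 4 (0.15 log units; that floor lies within the scatter). The value of compound 2 is a limit and not a number, so its step is only a floor: the limit of > 200000 nM in this assay, at which 1 of the 4 values shown sits.

Across these four compounds, then, no exchange at this oxygen yields a step beyond the scatter, and it remains open whether any group placed there would do so. An amine, a carboxylic acid or a longer chain on this oxygen, or a free hydroxyl in place of the whole group, could still give a different number, and the shared core itself is not varied in the compounds shown.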